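A few compounds are considered here, and "the series" means these few. Any claim that something is new, unique, unknown or untested is made for them only; others in the source may bear on it.

Measured in a functional assay on MCF7 cells (Homo sapiens) for antiproliferative activity; on this read-out higher numbers stand for weaker inhibition and lower numbers for stronger inhibition:
- compound 1 `CC(C)=CCc1cc(C(=O)Nc2cc3ccc(OCCCN4CCCCC4)c(C)c3oc2=O)ccc1O`: > 50000 nM (a limit of the assay)
- compound 2 `CCNCCCOc1ccc2cc(NC(=O)c3ccc(O)c(CC=C(C)C)c3)c(=O)oc2c1C`: 980 nM
- compound 3 `COC(=O)CNCCCOc1ccc2cc(NC(=O)c3ccc(O)c(CC=C(C)C)c3)c(=O)oc2c1C`: 2820 nM

Compound 3 has the higher of the two true numbers, and its nearest neighbour is compound 2: a 2.9-fold higher number from compound 2 to compound 3 (0.46 log units; beyond the scatter). The next change gives compound 4 `CC(C)=CCc1cc(C(=O)Nc2cc3ccc(OCCCNc4ccccc4)c(C)c3oc2=O)ccc1O`, with phenyl in place of (methoxycarbonyl)methyl on an amine nitrogen.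

Within the data shown here, the closest precedent is that same step from compound 2, which changes the same group on the same nitrogen and is modest. Two large steps also bear on the change, although both replace piperidin-1-yl: an at least 51-fold lower number from compound 1 to compound 2 (1.70 log units; beyond the scatter) and an at least 17-fold lower number from compound 1 to compound 3 (1.24 log units; beyond the scatter). Compound 4 keeps the secondary amine pattern of compounds 2 and 3, but it also brings a ring onto that nitrogen, as compound 1 does. In this assay, no shift beyond the scatter is therefore the central expectation, with the risk lying towards higher numbers.

The estimated change is a 1.4-fold higher number from compound 3 to compound 4 (0.15 log units; within the scatter). For compound 4 the expected value is 4000 nM, with an estimated range of 900 nM to 25000 nM.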

Compound 4, half-maximal inhibitory concentration: > 50000 nM
Compound 4: a limit, no number (the forecaster's own chance of this, stated with the estimate: 15%); middle value at least 12-fold (1.09 log units) away from the limit.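

In this assay, keeping a secondary amine does not by itself preserve a measurable value: with phenyl on the amine nitrogen, the result is an at least 17-fold higher number from compound 3 to compound 4 (1.24 log units; beyond the scatter) and an at least 51-fold higher number from compound 2 to compound 4 (1.70 log units; beyond the scatter). Compound 4 gives > 50000 nM, a limit of the assay; compound 1 also stands at a limit, and the step between the two cannot be read. A ring on this nitrogen now appears in both compounds at the limit, compound 1 and compound 4, while the open-chain groups of compound 2 and compound 3 give numbers: the limit of > 50000 nM in this assay, at which 2 of the 4 values shown sit.

Still open, from the compounds shown here alone, is whether any ring on this nitrogen gives this result, or only these two; a benzyl or cyclohexyl group would test that. Also open, going by these compounds, is how far the open-chain side extends, for example with a carboxylic acid in place of the methoxycarbonyl of compound 3.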